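Swapping the Aromatic Group on the Ring Nitrogen

The source may hold more compounds than are shown below. What is called first, only, known or untested is meant among the compounds shown, and "the series" means these compounds.

Measured so far:
compound 1 `Cc1ccc(-n2nc(C(=O)Nc3ccc(Oc4ncnc5[nH]ccc45)c(F)c3)c(C)cc2=O)cc1` gives 18800 nM
compound 2 `Cc1cc(=O)n(-c2ccccc2OC(F)(F)F)nc1C(=O)Nc1ccc(Oc2ncnc3[nH]ccc23)c(F)c1` gives > 60000 nM

Both numbers come from a functional assay on HepG2 cells (Homo sapiens) for cytotoxicity, read by MTT assay, with a stated time of 72 h; a higher number here means a weaker inhibitor, a lower number a stronger inhibitor. Compound 2 stands at a limit of the assay rather than at a number: in this assay compound 2 reaches only > 60000 nM, a limit. Among the compounds with values here, the single measured step, an at least 3.1-fold higher number from compound 1 to compound 2 (0.50 log units; beyond the scatter), therefore rests on the limit of > 60000 nM in this assay, at which 1 of the 2 values shown sits, and its true size is not known.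

Compound 3 `Cc1cc(=O)n(-c2ccc(Br)cc2F)nc1C(=O)Nc1ccc(Oc2ncnc3[nH]ccc23)c(F)c1` carries 4-bromo-2-fluorophenyl in place of 2-(trifluoromethoxy)phenyl on an aromatic nitrogen. The new group shares the pattern of a substituent ortho to the ring nitrogen with compound 2, while its bromine sits para, where compound 1 carries its methyl group. Within the data shown here, with only the one step to draw on, and that one open at the top, a modest expected change is the most that can be said, and the direction is uncertain.

Compound 3 is expected to give about 40000 nM in this assay, between 15000 nM and 110000 nM, which would mean an at least 1.5-fold lower number from compound 2 to compound 3 (0.17 log units; that floor lies within the scatter).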

Compound 3, half-maximal inhibitory concentration: 32000 nM
Estimate against measurement, compound 3: 1.3-fold (0.10 log units) above; measured number inside the range.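

Compound 2 reaches only > 60000 nM in this assay, which is a limit and not a number. Replacing its 2-(trifluoromethoxy)phenyl group gives a measured value at this position, with an at least 1.8-fold lower number from compound 2 to compound 3 (0.27 log units; that floor lies within the scatter), so the true size of this change remains unknown, and the step rests on a limit: the limit of > 60000 nM in this assay, at which 1 of the 3 values shown sits.

The other step, a 1.7-fold higher number from compound 1 to compound 3 (0.23 log units; within the scatter), shows that the 4-bromo-2-fluorophenyl and 4-methylphenyl groups cannot be told apart in this assay.

From the compounds shown here alone, what a phenyl ring bearing an amine or a carboxylic acid would give on this ring nitrogen stays open. Also open, going by these compounds, is how the fluorine and the bromine of compound 3 each contribute to its value.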